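The source may hold more compounds than are shown below. What is called first, only, known or untested is meant among the compounds shown, and "the series" means these compounds.

Compound 3 `Cc1nnc(SCC(=O)c2ccccc2)n1N1C(=O)c2ccccc2C1=O` was tested in a functional assay on A549 cells (Homo sapiens) for cytotoxicity, read by MTT assay, with a stated time of 48 h; a lower number here means a stronger inhibitor, a higher number a weaker inhibitor. In this assay compound 3 gives only > 200000 nM, which is a limit of the assay rather than a number. Two close relatives share its core. Compound 1 `Cc1nnc(SCc2ccccc2)n1N1C(=O)c2ccccc2C1=O` carries a phenyl where compound 3 carries a benzoyl, and in this assay compound 1 likewise reaches only the limit > 200000 nM. Compound 2 `CCOC(=O)CSc1nnc(C)n1N1C(=O)c2ccccc2C1=O` carries an ethoxycarbonyl at that same place, and in this assay compound 2 again stops at the limit > 200000 nM. Because all three sit at the limit of > 200000 nM in this assay, at which 3 of the 3 values shown sit, the steps among them cannot be read: a step that the two limits leave unreadable from compound 1 to compound 2, a step that the two limits leave unreadable from compound 1 to compound 3 and a step that the two limits leave unreadable from compound 2 to compound 3.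

Compound 4 `C#CCSc1nnc(C)n1N1C(=O)c2ccccc2C1=O` is the next member. Its change from compound 3 is ethynyl in place of benzoyl on a saturated chain carbon bound to a sulfur. The three measured steps bear on it only in that each exchanged the group on the saturated chain carbon bound to a sulfur without producing a readable number; none gives a size or a direction. With every measured value at the limit, compound 4 is expected to show no step beyond the scatter in this assay, so the estimated step that the limit leaves unreadable from compound 3 to compound 4 is essentially nil. Compound 4 is therefore estimated at 250000 nM, with a range from 100000 nM to 1000000 nM, and most likely the assay again reports only a limit.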

Compound 4, half-maximal inhibitory concentration: > 200000 nM
Compound 4: no number, only a limit; the forecaster's own chance of this, stated with the estimate: 85%; the middle value lies beyond the limit too.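

In this assay compound 4 gives > 200000 nM, which is a limit and not a number. The steps linking compound 4 to compound 1, compound 2 and compound 3 therefore cannot be read: the limit of > 200000 nM in this assay, at which 4 of the 4 values shown sit.

The compounds shown leave open how strongly any of them inhibits, and whether exchanging the group at this place changes that at all.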